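Swapping a saturated ring for an aromatic one at the branch point

This account rests on a few compounds, and the source may have more. Where it says the series, first, only, none or still open, it means among the compounds named here.

Compound 2 `CS(=O)(=O)Nc1ccc(C(C(=O)NCc2ccc(C(F)(F)F)nc2SC2CCCCC2)C2CCCC2)cc1F` gives 103 nM in an assay on CHO cells for antagonist activity at transient receptor potential cation channel subfamily V member 1 (Homo sapiens), read by FLIPR (on this read-out higher numbers stand for weaker inhibition and lower numbers for stronger inhibition), and stands at the top of the three numbers: compound 1 `CC1CCN(c2nc(C(F)(F)F)ccc2CNC(=O)C(c2ccc(NS(C)(=O)=O)c(F)c2)C2CCCC2)CC1` gives 88.7 nM, and compound 3 `CC1CCN(c2nc(C(F)(F)F)ccc2CNC(=O)C(c2ccccc2)c2ccc(NS(C)(=O)=O)c(F)c2)CC1` gives 1.3 nM. Compound 4 `CS(=O)(=O)Nc1ccc(C(C(=O)NCc2ccc(C(F)(F)F)nc2SC2CCCCC2)c2cccc(F)c2)cc1F` differs from compound 2 by 3-fluorophenyl in place of cyclopentyl on a saturated chain carbon bound to an aromatic carbon and a carbonyl carbon. The closest measured step is the nearly identical exchange that gave a 68-fold lower number from compound 1 to compound 3 (1.83 log units; beyond the scatter), while a 1.2-fold higher number from compound 1 to compound 2 (0.06 log units; within the scatter) shows the group on the aromatic carbon mattered little. A similar large fall is therefore expected for compound 4, the fluorine on the entering ring being untested here, giving a 52-fold lower number from compound 2 to compound 4 (1.71 log units; beyond the scatter). Compound 4 is thus estimated at 2 nM, with a range of 0.5 nM to 10 nM.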

Compound 4, inhibition constant: 48.7 nM
Estimate against measurement, compound 4: 24-fold (1.39 log units) below; measured number outside the range, above it.
By their numbers in this assay, from the lowest: compound 3; then compounds 4, 1 and 2 (each within the scatter of the next, the first and the last beyond it).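

In this assay, an aromatic ring at this carbon gives only a 2.1-fold lower number from compound 2 to compound 4 (0.33 log units; beyond the scatter), a much smaller step than a 68-fold lower number from compound 1 to compound 3 (1.83 log units; beyond the scatter). The gain from replacing the saturated ring is therefore not constant: it differs between the compounds carrying cyclohexylsulfanyl and those carrying 4-methylpiperidin-1-yl, although the entering rings differ too. Nothing available explains why these two steps differ in size.

The compounds shown cannot separate the fluorine's part from that of the cyclohexylsulfanyl group, as unsubstituted phenyl is paired only with 4-methylpiperidin-1-yl. Going by these compounds, how a methyl group or an amine would behave at this carbon also remains open.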